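The source may report more compounds than this note shows. Statements on the series, on what has been measured and on what is new or still open speak of the compounds shown alone.

In a physicochemical assay for solubility, read by HPLC (on this read-out higher numbers stand for higher solubility and lower numbers for lower solubility), compound 1 `Cc1ccc([C@H](C(=O)N(C)C)N2C(=O)[C@@H](C3Cc4ccccc4C3)NC(=O)[C@H]2CC(C)C)cn1` gives > 236 ug/mL, which is a limit and not a number. Compound 2 `Cc1ccc([C@H](C(=O)N(C)C)N2C(=O)[C@@H](C3Cc4ccccc4C3)NC(=O)[C@H]2CC(C)(C)C)cn1` gives > 242 ug/mL, also a limit. Compound 3 `COc1ccc([C@H](C(=O)N(C)C)N2C(=O)[C@@H](C3Cc4ccccc4C3)NC(=O)[C@H]2CC(C)C)cn1` has methoxy in place of methyl on an aromatic carbon, next to the ring nitrogen: methoxy in place of methyl on an aromatic carbon. Within the data shown here, the only measured step, a step that the two limits leave unreadable from compound 1 to compound 2, lies on a saturated chain carbon elsewhere and has no readable size, so it offers little guidance. No change beyond the scatter is therefore expected in this assay, and the expected step is an at least 1.0-fold lower number from compound 1 to compound 3 (0.03 log units; that floor lies within the scatter). The estimate for compound 3 is 220 ug/mL, with an expected range of 90 ug/mL to 320 ug/mL.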

Compound 3, solubility: 216 ug/mL
Estimate against measurement, compound 3: 1.0-fold (0.01 log units) above; measured number inside the range.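

In this assay compound 3 gives 216 ug/mL, the only number among the compounds shown. Methoxy in place of methyl on this aromatic carbon, next to the ring nitrogen, gives an at least 1.0-fold lower number from compound 1 to compound 3 (0.03 log units; that floor lies within the scatter), so the change has no readable effect beyond the scatter. Compound 1 stands only as a limit, which leaves the step with a floor and no full size: the limit of > 236 ug/mL in this assay, at which 1 of the 3 values shown sits.

From the compounds shown here alone, how far the true step lies from that floor stays open. So does how an amine or a longer chain such as ethoxy on this carbon would read.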